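Methyl for Bromo at the Limit of the Assay

The source may hold more compounds than are shown below. What is called first, only, known or untested is meant among the compounds shown, and "the series" means these compounds.

In an ADME assay on T29 cells (Homo sapiens) for cytotoxicity, read by sulforhodamine B assay, with a stated time of 3 days (on this read-out lower numbers stand for stronger inhibition and higher numbers for weaker inhibition), compound 1 (`O=Cc1cn(Cc2ccc(Cl)cc2)c2cc(F)ccc12`) gives > 31600 nM as a limit of the assay. Compound 2 (`OCc1cn(Cc2ccc(Cl)cc2)c2ccccc12`) likewise gives > 31600 nM as a limit. Compound 3 (`OCc1cn(Cc2ccc(Br)cc2)c2ccccc12`) gives > 31600 nM as a limit too, so it has no number of its own. The change to compound 4 (`Cc1ccc(Cn2cc(CO)c3ccccc32)cc1`) is methyl in place of bromo on an aromatic carbon. For the measured compounds named here, the one measured step at this place (a step that the two limits leave unreadable from compound 2 to compound 3) is bromo in place of chloro and has no readable size. Going by the values given here, the measurements offer only the limit of > 31600 nM in this assay, at which 3 of the 3 values shown sit, and no step of readable size, so no step beyond the scatter is expected. The expected step is therefore small (a step that the limit leaves unreadable from compound 3 to compound 4) and another limit is likely. In this assay the estimate for compound 4 is 35000 nM with an expected range of 12000 nM to 60000 nM around it.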

Compound 4, half-maximal inhibitory concentration: > 31600 nM
Compound 4 was reported as a limit; the forecaster's own chance of this, stated with the estimate: 85%; the middle value is on the limit's open side.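

For the compounds shown here, compound 4 gives > 31600 nM, again a limit of the assay, so no step from compound 2 or compound 3 to compound 4 can be read. The compounds shown leave open what actual value any of them has: the limit of > 31600 nM in this assay, at which 4 of the 4 values shown sit.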